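From methoxy to isopropyl in a weakly active series

This account rests on a few compounds, and the source may have more. Where it says the series, first, only, none or still open, it means among the compounds named here.

Three compounds of this small set share one core, and only one of them carries a number in an assay on cells for inhibition of Amine oxidase [flavin-containing] A (Homo sapiens), read by fluorescence, with stated times of 30 min and 15 min; a lower number here means a stronger inhibitor, a higher number a weaker inhibitor. Compound 1 `COc1ccc(OCCOc2ccc3[nH]c(=O)n(C(C)C)c3c2)cc1` is entered in this assay as "not determined" (no result reported), and compound 2 `CCn1c(=O)[nH]c2ccc(OCCOc3ccc(OC)cc3)cc21` is entered as "not determined" (no result reported). Compound 3 `CCn1c(=O)[nH]c2ccc(OCCOc3cccc(F)c3)cc21` is reported only as a limit of the assay, > 500000 nM, and no value was fixed for it. So compound 2 stands without a number: one neighbour sits at a limit, the other has no entry, a situation summed up by the limit of > 500000 nM in this assay, at which 1 of the 3 values shown sits.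

The step considered here goes from compound 2 to compound 4 `CCn1c(=O)[nH]c2ccc(OCCOc3ccc(C(C)C)cc3)cc21`. The change is isopropyl in place of methoxy on an aromatic carbon, an isopropyl in place of methoxy on an aromatic carbon. Within the data shown here, no measured step is available to calibrate it, and the only number nearby is a limit, so the direction of the step cannot be read from the data; the writer expects no change beyond the usual scatter, with the outcome most likely again a weak result. Compound 4 is therefore estimated to sit near 300000 nM, within a range from 30000 nM to 1000000 nM, and it is expected that this assay may again report only a limit.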

Compound 4, half-maximal inhibitory concentration: > 500000 nM
Compound 4: a limit, no number; the forecaster's own chance of this, stated with the estimate: 60%; middle value at least 1.6-fold (0.22 log units) away from the limit.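

Compound 4 is again reported only as a limit of the assay, > 500000 nM, and not as a number. Among these compounds, compound 2 has no number either, so no step from compound 2 to compound 4 can be read. The compounds shown leave open what isopropyl in place of methoxy does in this assay, and where any of them would fall as a number: the limit of > 500000 nM in this assay, at which 2 of the 4 values shown sit.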